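This account rests on a few compounds, and the source may have more. Where it says the series, first, only, none or still open, it means among the compounds named here.

Measured compounds:
- compound 1 `C#CCOc1ccc(/C=C/C(=O)c2ccc(OC)cc2)cc1` — 25%
- compound 2 `O=C(/C=C/c1ccc(OCc2cn(Cc3ccccc3Br)nn2)cc1)c1ccc(Br)cc1` — 34%
- compound 3 `COc1ccc(C(=O)/C=C/c2ccc(OCc3cn(Cc4ccccc4Br)nn3)cc2)cc1` — 44%

In a functional assay on HepG2 cells (Homo sapiens) for inhibition, read by MTT assay, with a stated time of 48 h, tested at 10 uM (on this read-out lower numbers stand for less inhibition of growth and higher numbers for more inhibition of growth at the one concentration tested), compound 3 gives 44%, the largest of the three numbers shown. The step of a number 10 percentage points higher from compound 2 to compound 3 (within the scatter) lies within the scatter; only compound 1 sits beyond the scatter below compound 3, compound 1 giving 25% in this assay.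

Compound 4 `COc1ccc(C(=O)/C=C/c2ccc(OCc3cn(Cc4ccccc4F)nn3)cc2)cc1` is not yet measured. It differs from compound 3 by fluoro in place of bromo on an aromatic carbon. For the measured compounds named here, the one measured step, a number 10 percentage points higher from compound 2 to compound 3 (within the scatter), concerns an exchange of bromo on another aromatic carbon of the series, and it stayed within the scatter. Going by the values given here, no measured pair shows an exchange of bromo for fluoro, so the step from compound 3 to compound 4 has no direct precedent. Given that the only halogen exchange seen, a number 10 percentage points higher from compound 2 to compound 3 (within the scatter), did not move the number beyond the scatter, the expectation for compound 4 is a step of a number 2 percentage points lower from compound 3 to compound 4 (within the scatter) in this assay, that is no change beyond the scatter. Compound 4 is therefore estimated at 42%, with a range from 30% to 54%.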

Compound 4, percent growth inhibition at one concentration: 33%
The estimate for compound 4 lay 9 percentage points above the measured number; the range from low to high includes it.
By their numbers in this assay, from the lowest: compounds 1, 4, 2 and 3 (each within the scatter of the next, the first and the last beyond it).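

In this assay, for the compounds shown here, replacing the 2-bromobenzyl group of compound 3 with the 2-fluorobenzyl group of compound 4 gives a number 11 percentage points lower from compound 3 to compound 4 (beyond the scatter), the first one-place change to pass beyond the scatter. The halogen on this aromatic carbon, ortho to a large group, therefore affects growth inhibition at the one concentration tested, although the step is modest and rests on a single pair. No available measurement explains the step.

Going by these compounds, it remains open how a chloro, amine or methoxy group at this position would compare with bromo and fluoro. Also open, on these data alone, is whether fluoro in place of the bromo that compound 2 carries on its other aromatic ring would give a step of similar size.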